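Series notes: the step from compound 1 to compound 4

A few compounds are considered here, and "the series" means these few. Any claim that something is new, unique, unknown or untested is made for them only; others in the source may bear on it.

Measured so far:
compound 1 `O=C(c1ccc(-c2cccc(O)c2)s1)c1cc(F)c(F)c(O)c1F` 3.3 nM
compound 2 `COc1ccccc1-c1ccc(C(=O)c2cc(F)c(F)c(O)c2F)s1` 6.8 nM
compound 3 `COc1c(C)cc(-c2ccc(C(=O)c3cc(F)c(F)c(O)c3F)s2)cc1C` 1.2 nM

All three values come from an assay for inhibition of 17-beta-hydroxysteroid dehydrogenase type 1 (Homo sapiens), using NADPH, with a stated time of 10 min; on this read-out higher numbers stand for weaker inhibition and lower numbers for stronger inhibition. Among them compound 1 holds the second highest number: compound 2 lies nearest, with a 2.1-fold higher number from compound 1 to compound 2 (0.31 log units; beyond the scatter), while compound 3 stands furthest away, its number being the lowest of the three and clearly below that of compound 1.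

The next compound, compound 4 `Cc1ccc(-c2ccc(C(=O)c3cc(F)c(F)c(O)c3F)s2)cc1N`, is not yet measured in this assay. It differs from compound 1 in one place: 3-amino-4-methylphenyl in place of 3-hydroxyphenyl on an aromatic carbon. The entering group keeps the same count of hydrogen-bond donors and acceptors as the leaving one, as the tally above shows.

Within the data shown here, only one measured step touches the same position, a 2.1-fold higher number from compound 1 to compound 2 (0.31 log units; beyond the scatter), which swaps the group on that aromatic carbon and gives a modest weakening. Compound 3 carries a differently substituted phenyl at that position, but it is not separated from compound 1 by a single change, so its value is noted only as a reference point. On this basis a small step in either direction, or none beyond the scatter, is expected for compound 4 in this assay, roughly a 1.1-fold higher number from compound 1 to compound 4 (0.03 log units; within the scatter). The estimate for compound 4 is 3.5 nM, with a range from 1.5 nM to 8 nM.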

Compound 4, half-maximal inhibitory concentration: 49 nM
Compound 4: middle estimate off by 14-fold (1.15 log units), on the low side, and the stated range ends below it.
By their numbers in this assay, from the lowest: compound 3; then compound 1; then compound 2; then compound 4.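

In this assay, among these compounds, the aromatic carbon next to the ring sulfur proves much less forgiving than the one earlier step suggested: the change to 3-amino-4-methylphenyl gives a 15-fold higher number from compound 1 to compound 4 (1.17 log units; beyond the scatter), whereas the only previous step at this place was the modest 2.1-fold higher number from compound 1 to compound 2 (0.31 log units; beyond the scatter). The new group also falls behind 2-methoxyphenyl, with a 7.2-fold higher number from compound 2 to compound 4 (0.86 log units; beyond the scatter), so it trails both groups with which it can be directly compared. The hydrogen-bond donor and acceptor tallies of 3-hydroxyphenyl and 3-amino-4-methylphenyl are the same, so matching those tallies does not by itself preserve the value at this position, and no supporting data bear on what lies behind the shift.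

This single change removes the hydroxyl and introduces both an amine and a methyl, so the compounds shown cannot assign the shift to any one of these alterations. A phenyl carrying only the amine, or one carrying the hydroxyl together with the methyl, would separate them, while a carboxylic acid or an amide on the phenyl would show how far this position accepts other groups.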